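A few compounds are considered here, and "the series" means these few. Any claim that something is new, unique, unknown or untested is made for them only; others in the source may bear on it.

Measured so far:
- compound 1, `Cc1ccc(-n2nccn2)c(C(=O)N(C)CCn2ccc(-c3ccc(F)cn3)n2)c1`: 11.9 nM
- compound 2, `Cc1ccc(-n2nccn2)c(C(=O)N[C@@H](C)Cn2cc(-c3ccc(F)cn3)cn2)c1`: 840 nM

Compound 1, with the structure `Cc1ccc(-n2nccn2)c(C(=O)N(C)CCn2ccc(-c3ccc(F)cn3)n2)c1`, has been tested in a functional assay on cells for antagonist activity at Orexin receptor type 2 (Homo sapiens), read by fluorescence and calcium flux, with a stated time of 30 min (a lower number here means a stronger inhibitor, a higher number a weaker inhibitor), and gives 11.9 nM. Compound 2, with the structure `Cc1ccc(-n2nccn2)c(C(=O)N[C@@H](C)Cn2cc(-c3ccc(F)cn3)cn2)c1`, gives 840 nM in this assay. Compound 1 therefore holds the lowest of the two numbers, and the gap to compound 2 is far beyond the usual scatter. Within the data shown here, the two compounds differ in more than one place, so the comparison says only that these two values sit far apart; no single change can be read from it.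

Compound 3, with the structure `Cc1ccc(-n2nccn2)c(C(=O)N(C)[C@@H](C)Cn2ccc(-c3ccc(F)cn3)n2)c1`, has not yet been measured. It keeps everything in compound 1 and differs by methyl in place of hydrogen on a saturated chain carbon bound to an amide-type nitrogen and a saturated chain carbon. Among the measured compounds shown here, no measured pair shows this exact change, so the expectation rests on compound 1 alone and the step is uncertain in direction. A small methyl added to the chain in this way is expected to leave the value of compound 1 roughly where it is, within or close to the scatter, so the step of a 1.3-fold higher number from compound 1 to compound 3 (0.10 log units; within the scatter) is expected to be small. Compound 3 is estimated at 15 nM, within a range from 4 nM to 60 nM.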

Compound 3, half-maximal inhibitory concentration: 5.68 nM
For compound 3 the middle estimate is 2.6-fold (0.42 log units) above the measured one, and the stated range covers the measured number.
By their numbers in this assay, from the lowest: compound 3; then compound 1; then compound 2.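

Compound 1 and compound 2 differ in more than one place, so their gap could not be tied to any single change. Here one change stands alone: methyl in place of hydrogen, on a saturated chain carbon bound to an amide-type nitrogen and a saturated chain carbon, gives a 2.1-fold lower number from compound 1 to compound 3 (0.32 log units; beyond the scatter) in this assay. The step is modest, but it shows that this chain carbon can carry a methyl with a small gain rather than a loss, and nothing measured here says why the number falls.

From the compounds shown here alone, a single methyl is only one point at this carbon, so it remains open whether a larger group there, such as ethyl or hydroxymethyl, would lower the number further or raise it again. Going by these compounds, this carbon also has a fixed spatial arrangement in compound 3, and what the mirror-image arrangement would give is equally open.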